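The source may report more compounds than this note shows. Statements on the series, on what has been measured and on what is new or still open speak of the compounds shown alone.

Measured so far, in an assay on cells (Macrophage) for inhibition of sterol O-acyltransferase 1 (Mus musculus); a higher number here means a weaker inhibitor, a lower number a stronger inhibitor:
Compound 1, `CCCCCCN(CCCCCSc1nc2ccccc2o1)C(=O)Nc1ccc(F)cc1F`, gives 3500 nM.
Compound 2, `CCCCCCN(CCCCCSc1nc2c([nH]1)CCCC2)C(=O)Nc1ccc(F)cc1F`, gives 2580 nM.

Among the measured compounds shown here, compound 2 holds the lower of the two numbers, but its only neighbour is compound 1, and the step of a 1.4-fold lower number from compound 1 to compound 2 (0.13 log units; within the scatter) lies within the scatter, so the two compounds cannot be told apart on these data.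

Compound 3, `CCCCCCN(CCCCCSc1nc2cc(C)ccc2[nH]1)C(=O)Nc1ccc(F)cc1F`, has not yet been measured. It differs from compound 2 in one place: a group of 10 heavy atoms (8 carbon, 2 nitrogen; one five-membered aromatic ring with 2 hetero atoms, one six-membered aromatic ring of carbon only) in place of a group of 9 heavy atoms (7 carbon, 2 nitrogen; one five-membered aromatic ring with 2 hetero atoms, one six-membered non-aromatic ring of carbon only), on a sulfur. The ring pair on the sulfur thus becomes aromatic again and carries a methyl, while the hydrogen-bond donor and acceptor count of the group stays the same.

For the measured compounds named here, only one measured step touches this part of the molecule, the exchange of the sulfur-bound group from compound 1 to compound 2, and it produced a 1.4-fold lower number from compound 1 to compound 2 (0.13 log units; within the scatter), a change within the scatter. Nothing in the data, therefore, suggests that swapping the group on the sulfur moves this assay by much. Compound 3 is expected to stay close to compound 2, with a step of a 1.0-fold lower number from compound 2 to compound 3 (0.01 log units; within the scatter) that is not beyond the scatter. The estimate for compound 3 is 2500 nM, within 1000 nM to 6500 nM.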

Compound 3, half-maximal inhibitory concentration in the sterol O-acyltransferase 1 assay: 2060 nM
Compound 3: the middle estimate sits 1.2-fold (0.08 log units) above what was measured; the range from low to high includes it.
By their numbers in the sterol O-acyltransferase 1 assay, from the lowest: compounds 3, 2 and 1 (each within the scatter of the next).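

In the sterol O-acyltransferase 1 assay, both new steps, a 1.3-fold lower number from compound 2 to compound 3 (0.10 log units; within the scatter) and a 1.7-fold lower number from compound 1 to compound 3 (0.23 log units; within the scatter), stay within the scatter, so the three groups on the sulfur, including 5-methyl-1H-benzimidazol-2-yl and 1,3-benzoxazol-2-yl, cannot be told apart. The change from compound 2 to compound 3 is nonetheless not a silent one, for in a physicochemical assay for lipophilicity (a higher number here means a more lipophilic compound, a lower number a more polar compound), compound 2 gives 6.81 and compound 3 gives 7.79, which is a number 0.98 log units higher from compound 2 to compound 3 (beyond the scatter). Among the compounds shown here, for this pair, then, the group on the sulfur shifts lipophilicity clearly, with no readable matching shift in inhibition, which the earlier compounds could not show: the measured partition coefficient of compound 2, 6.81, and of compound 3, 7.79, a number 0.98 log units higher (beyond the scatter).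

On these data alone, the step from compound 2 to compound 3 alters the ring and adds the methyl in one move, so what the methyl contributes alone stays open, and 1H-benzimidazol-2-yl without it would separate the two. Also open is whether any group on the sulfur moves inhibition beyond the scatter, for instance a ring of this kind carrying a carboxylic acid or an amine, as all three groups shown are uncharged and give numbers that cannot be separated.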